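A few compounds are considered here, and "the series" means these few. Any claim that something is new, unique, unknown or untested is made for them only; others in the source may bear on it.

Measured compounds and their values:

compound 1 `N#Cc1ccc(-c2cc(-c3ccc(C(N)=O)cc3)cc(-c3ccco3)n2)cc1` — 3000 nM
compound 2 `Cn1ccnc1-c1cc(-c2ccc(C(N)=O)cc2)cc(-c2ccc(C#N)cc2)n1` — 40000 nM

In an assay on cells for binding affinity to Myc proto-oncogene protein (Homo sapiens) (on this read-out lower numbers stand for stronger inhibition and higher numbers for weaker inhibition), compound 1 gives 3000 nM and stands with the lowest number of the two measured; compound 2, the nearest to it, gives 40000 nM. Among the compounds with values here, the single measured step in this assay is a 13-fold higher number from compound 1 to compound 2 (1.12 log units; beyond the scatter); it concerns the exchange of one ring on the shared core and is large.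

Compound 3 `N#Cc1ccc(-c2cc(-c3ccc(C(=O)NN)cc3)cc(-c3ccco3)n2)cc1` is not yet measured. Against compound 1 it carries amino in place of hydrogen on an amide-type nitrogen; cut one bond further out, the change reads carbamoyl to aminocarbamoyl. Within the data shown here, no measured step in this assay touches the carbamoyl group, so the step from compound 1 to compound 2 does not bear on this change directly; it only shows that this assay can resolve large steps. With nothing to anchor a direction, the expectation for compound 3 is a step no larger than the scatter, no change at the digits printed from compound 1 to compound 3 (within the scatter), in either direction. The estimate for compound 3 in this assay is therefore 3000 nM, with a range from 1000 nM to 10000 nM.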

Compound 3, half-maximal inhibitory concentration: > 100000 nM
Compound 3 ended at the assay's limit (the forecaster's own chance of this, stated with the estimate: 10%); at least 33-fold (1.52 log units) between middle value and limit.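

In this assay compound 3 gives > 100000 nM, which is a limit of the assay and not a number. The carbamoyl group, untouched by the earlier step, proves to be a sensitive place in the series: amino in place of hydrogen on the amide-type nitrogen, a change of one heavy atom, gives an at least 33-fold higher number from compound 1 to compound 3 (1.52 log units; beyond the scatter), and this joins a 13-fold higher number from compound 1 to compound 2 (1.12 log units; beyond the scatter) as a second large step away from compound 1, now at a different place on the molecule. The full size of the new step cannot be read, only its lower bound: the limit of > 100000 nM in this assay, at which 1 of the 3 values shown sits.

With a single change shown at this nitrogen, the compounds do not tell whether the drop belongs to amino in particular or to any group replacing the amide hydrogen; a methyl group on that nitrogen, or a carboxylic acid in place of the carbamoyl group, would separate these readings. They also leave open whether the aminocarbamoyl group would act the same way on the core of compound 2, which carries 1-methyl-1H-imidazol-2-yl in place of furan-2-yl.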